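A few compounds are considered here, and "the series" means these few. Any claim that something is new, unique, unknown or untested is made for them only; others in the source may bear on it.

Measured compounds in an assay on isolated protein for antagonist activity at transient receptor potential cation channel subfamily M member 8 (Homo sapiens), read by luminescence and calcium flux, with a stated time of 2.5 min; a lower number here means a stronger inhibitor, a higher number a weaker inhibitor:
compound 1 `O=C(Nc1cccnc1)N1CCc2ccccc2[C@H]1c1ccc(C(F)(F)F)cc1`: 28 nM
compound 2 `O=C(Nc1ccc(F)cc1)N1CCc2cccnc2[C@H]1c1ccc(C(F)(F)F)cc1`: 14 nM
compound 3 `O=C(Nc1ccc(F)cc1)N1CCc2nccnc2[C@H]1c1ccc(C(F)(F)F)cc1`: 200 nM

Compound 2 holds the lowest number of the three in this assay, though compound 1 sits within the scatter of it; only compound 3 is set apart, beyond the scatter. Compound 4 `O=C(Nc1cccnc1)N1CCc2cccnc2[C@H]1c1ccc(C(F)(F)F)cc1` has not been measured. It differs from compound 2 by pyridin-3-yl in place of 4-fluorophenyl on an amide-type nitrogen. Among the compounds with values here, no pair of measured compounds differs in one place, so no measured step can be carried over; compound 1 already carries the pyridin-3-yl urea on a different core and gives 28 nM. For compound 4 a step of a 2.1-fold higher number from compound 2 to compound 4 (0.33 log units; beyond the scatter) is expected, a small move toward a higher number, within the scatter. Compound 4 is estimated at 30 nM, with a range from 10 nM to 90 nM.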

Compound 4, half-maximal inhibitory concentration: 24 nM
Compound 4: middle estimate off by 1.3-fold (0.10 log units), on the high side; low and high end bracket the measured number.
By their numbers in this assay, from the lowest: compounds 2, 4 and 1 (each within the scatter of the next); then compound 3.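

In this assay pyridin-3-yl in place of 4-fluorophenyl on the amide-type nitrogen gives a 1.7-fold higher number from compound 2 to compound 4 (0.23 log units; within the scatter) and so leaves the number within the scatter. Within the data shown here, this is the only one-place comparison, and it shows that on this shared core the position accepts a ring with a hetero atom as well as a carbon-only ring bearing fluorine. No measurement shown accounts for this step.

From the compounds shown here alone, whether a morpholine or an unsubstituted phenyl on this nitrogen stays in the same range remains open. Also open, going by these compounds, is whether pyridin-3-yl gives a similar step on the core of compound 3.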